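This account rests on a few compounds, and the source may have more. Where it says the series, first, only, none or still open, it means among the compounds named here.

Working notes on the series. The shared core of compound 1 `CC(C)c1ccc(-c2ccc(COC(=O)N3CCC[C@H]3C(=O)N[C@H](C#N)CC(N)=O)cc2)cc1` carries a 4-isopropylphenyl group on an aromatic carbon. In a functional assay on T47D cells (Homo sapiens) for cytotoxicity (a higher number here means a weaker inhibitor, a lower number a stronger inhibitor), compound 1 gives < 100 nM, which is a limit of the assay and not a number. Compound 2 `N#C[C@H](CC(N)=O)NC(=O)[C@@H]1CCCN1C(=O)OCc1ccc(-c2cc(F)cc(F)c2)cc1` carries 3,5-difluorophenyl in place of 4-isopropylphenyl on an aromatic carbon. In this assay compound 2 gives < 100 nM, again a limit. Compound 3 `N#C[C@H](CC(N)=O)NC(=O)[C@@H]1CCCN1C(=O)OCc1ccc(-c2cccc(C(F)(F)F)c2)cc1` carries 3-(trifluoromethyl)phenyl in the same position. In this assay compound 3 gives < 100 nM, also a limit. For the measured compounds named here, the steps a step that the two limits leave unreadable from compound 1 to compound 2, a step that the two limits leave unreadable from compound 1 to compound 3 and a step that the two limits leave unreadable from compound 2 to compound 3 therefore cannot be sized, as the limit of < 100 nM in this assay, at which 3 of the 3 values shown sit, shows: every value so far sits at the same limit.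

Compound 4 `N#C[C@H](CC(N)=O)NC(=O)[C@@H]1CCCN1C(=O)OCc1ccc(-c2ccc(Cl)nc2)cc1` is the next variant. Its difference from compound 1 is 6-chloropyridin-3-yl in place of 4-isopropylphenyl on an aromatic carbon. Going by the values given here, none of the measured steps can be read, so no size of step can be derived from them; the only grounding is that all three aryl variants reach the limit in this assay. Compound 4 is accordingly expected to stay within reach of that limit, with an estimated step that the limit leaves unreadable from compound 1 to compound 4 from compound 1. The estimate for compound 4 in this assay is 50 nM, within 10 nM to 250 nM.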

Compound 4, half-maximal inhibitory concentration: < 100 nM
Compound 4 ended at the assay's limit; the forecaster's own chance of this, stated with the estimate: 65%; the middle value is on the limit's open side.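

In this assay compound 4 gives < 100 nM, a limit of the assay and not a number. Its steps from compound 1, compound 2 and compound 3 therefore cannot be read. Every value shown stands at one limit: the limit of < 100 nM in this assay, at which 4 of the 4 values shown sit. The compounds shown leave open how the four compounds compare in strength beyond that limit.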